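A few compounds are considered here, and "the series" means these few. Any claim that something is new, unique, unknown or untested is made for them only; others in the source may bear on it.

Compound 1 `C/N=C(\NC#N)Nc1cccnc1` is the reference point here. In a functional assay on the whole organism (blood, strain Wistar-Okamoto) with Rattus norvegicus as the target, with a stated time of 5 days (a lower number here means that less compound is needed, a higher number that more compound is needed for the effect), compound 1 gives only a limit, > 50 mg/kg, and not a number. Compound 1 therefore sits at the limit of > 50 mg/kg in this assay, at which 1 of the 3 values shown sits. Compound 4 `N#CN/C(=N\C1CC1)Nc1cccnc1` has not yet been measured; it differs from compound 1 by cyclopropyl in place of methyl on a double-bonded nitrogen. Going by the values given here, two measured steps bear on this change, each replacing the methyl on the double-bonded nitrogen with a larger alkyl group. Compound 2 `CCCCC/N=C(\NC#N)Nc1cccnc1` gives 20 mg/kg in this assay, which amounts to an at least 2.5-fold lower number from compound 1 to compound 2 (0.39 log units; beyond the scatter). Compound 3 `CCC(C)/N=C(\NC#N)Nc1cccnc1` gives 20 mg/kg, a step of an at least 2.5-fold lower number from compound 1 to compound 3 (0.39 log units; beyond the scatter). Between these two alkyl groups there is no change at the digits printed from compound 2 to compound 3 (within the scatter). Since both an at least 2.5-fold lower number from compound 1 to compound 2 (0.39 log units; beyond the scatter) and an at least 2.5-fold lower number from compound 1 to compound 3 (0.39 log units; beyond the scatter) point the same way, a step of similar direction is expected for cyclopropyl, though its size cannot be fixed closely from a limit. Compound 4 is expected to give 25 mg/kg, with a range of 10 mg/kg to 60 mg/kg. This estimate means an expected step of an at least 2.0-fold lower number from compound 1 to compound 4 (0.30 log units; that floor lies within the scatter).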

Compound 4, minimum effective dose: 20 mg/kg
The estimate for compound 4 lay 1.3-fold (0.10 log units) above the measured number, within the range that was stated.
By their numbers in this assay, from the lowest: compounds 2, 3 and 4 (each within the scatter of the next). At a limit, above all of these: compound 1.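

In this assay, the new result shows that the double-bonded nitrogen accepts a small ring as well as an open chain: cyclopropyl in place of methyl gives an at least 2.5-fold lower number from compound 1 to compound 4 (0.39 log units; beyond the scatter). Set against the open chains, cyclopropyl gives no change at the digits printed from compound 3 to compound 4 (within the scatter) and no change at the digits printed from compound 2 to compound 4 (within the scatter), so the three groups cannot be told apart here, even though cyclopropyl carries a ring and the others do not. The first of these steps remains only a floor because of where compound 1 stands, which is a limit and not a number: the limit of > 50 mg/kg in this assay, at which 1 of the 4 values shown sits.

The compounds shown leave open whether a larger ring such as cyclohexyl, an aromatic ring such as phenyl, or a chain longer than pentyl would lower the number further. They also leave open whether a hydroxyl or an amine on the chain would keep the number where it is.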